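Adding a second methoxy group to compound 2

The source may report more compounds than this note shows. Statements on the series, on what has been measured and on what is new or still open speak of the compounds shown alone.

For the measured compounds named here, in a functional assay on the whole organism with Rattus norvegicus as the target (a higher number here means that more compound is needed for the effect, a lower number that less compound is needed), compound 2 (`CCOC(=O)C(=O)Nc1nc(-c2ccc(OC)cc2)cs1`) gives about 10 mg/kg, the only actual number so far. Compound 1 (`CCOC(=O)C(=O)Nc1nc(-c2ccccc2OC)cs1`), which carries its methoxy group ortho to a large group, gives > 30 mg/kg, and this is a limit. Compound 3 (`CCOC(=O)C(=O)Nc1nc(-c2ccc(Oc3ccccc3)cc2)cs1`) gives > 30 mg/kg, also a limit. Also to be kept in view is the limit of > 30 mg/kg in this assay, at which 2 of the 3 values shown sit.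

The next compound is compound 4 (`CCOC(=O)C(=O)Nc1nc(-c2ccc(OC)cc2OC)cs1`). The change from compound 2 is methoxy in place of hydrogen on an aromatic carbon, so methoxy enters in place of hydrogen, ortho to a large group and meta to a methoxy group.

Going by the values given here, no measured step makes this exact change. The nearest measured step is an at least 3.0-fold higher number from compound 2 to compound 3 (0.47 log units; beyond the scatter), which has phenyl in place of methyl on an oxygen and lies beyond the scatter. It shows that this assay can respond to a change on this aromatic ring, with the number rising. Compound 1 at > 30 mg/kg, a limit, adds weight to the same direction for a methoxy group ortho to a large group.

A modest rise is therefore expected, estimated as a 2.0-fold higher number from compound 2 to compound 4 (0.30 log units; within the scatter). For compound 4 the estimated value is 20 mg/kg, with an expected range of 7 mg/kg to 60 mg/kg.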

Compound 4, dose for half-maximal effect: > 30 mg/kg
Compound 4 gave a limit, no number; the forecaster's own chance of this, stated with the estimate: 45%; middle value at least 1.5-fold (0.17 log units) away from the limit.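

In this assay, for the compounds shown here, methoxy in place of hydrogen on the aromatic carbon ortho to a large group gives an at least 3.0-fold higher number from compound 2 to compound 4 (0.47 log units; beyond the scatter), the first readable step for a change at this position with the methoxy group of compound 2 kept in place. The earlier step at the oxygen of that methoxy group concerned a different place on the molecule, so this result shows that adding to the ring itself also raises the number beyond the scatter, and that the remaining methoxy group, now meta to the new one, does not hold the number near that of compound 2. The step between compound 1 and compound 4 cannot be read, and compound 2 remains the only compound with an actual number, leaving the series mostly at one ceiling: the limit of > 30 mg/kg in this assay, at which 3 of the 4 values shown sit.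

Going by these compounds, how far compound 4 lies past its limit stays open, so the true size of the step is unknown. Also open, on these data alone, is whether a fluorine atom or a hydroxyl group ortho to a large group, or a carboxylic acid in place of the ethyl ester, would bring the number back towards that of compound 2.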